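Shrinking the amino substituent on the shared core

The source may hold more compounds than are shown below. What is called first, only, known or untested is meant among the compounds shown, and "the series" means these compounds.

Compound 1 `CCCCN(CCC)c1nc(C)nc2c(-c3c(C)cc(N(C)C)nc3C)c(C)nn12` gives 12.8 nM in an assay on cell membranes for displacement of a labelled ligand from corticotropin-releasing factor receptor 1 (Rattus norvegicus); a lower number here means a stronger inhibitor, a higher number a weaker inhibitor.
Compound 2 `CCCN(CCC)c1nc(C)nc2c(-c3c(C)cc(N(C)C)nc3C)c(C)nn12` gives 14.9 nM in this assay.
Compound 3 `CCN(CC)c1nc(C)nc2c(-c3c(C)cc(N(C)C)nc3C)c(C)nn12` gives 58 nM in this assay.

Compound 3 stands highest of the three: the steps of a 4.5-fold higher number from compound 1 to compound 3 (0.66 log units; beyond the scatter) and a 3.9-fold higher number from compound 2 to compound 3 (0.59 log units; beyond the scatter) both lie beyond the scatter, whereas a 1.2-fold higher number from compound 1 to compound 2 (0.07 log units; within the scatter) does not. Compound 4 `COCCNc1nc(C)nc2c(-c3c(C)cc(N(C)C)nc3C)c(C)nn12` carries (2-methoxyethyl)amino in place of diethylamino on an aromatic carbon. For the measured compounds named here, the steps that bear on this are the two that trimmed the amino substituent, each a modest rise in the number; compound 4 trims it further and no measured compound shows what that brings, so the expectation is uncertain. A further modest rise is expected in this assay. Compound 4 is expected to give 200 nM, within a range from 60 nM to 700 nM. The expected step is a 3.4-fold higher number from compound 3 to compound 4 (0.54 log units; beyond the scatter).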

Compound 4, half-maximal inhibitory concentration: > 10000 nM
Compound 4 ended at the assay's limit; the forecaster's own chance of this, stated with the estimate: 5%; middle value at least 50-fold (1.69 log units) away from the limit.
By their numbers in this assay, from the lowest: compounds 1 and 2 (each within the scatter of the next); then compound 3. At a limit, above all of these: compound 4.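

Compound 4's result is a limit of this assay, not a number: the limit of > 10000 nM in this assay, at which 1 of the 4 values shown sits. Although (2-methoxyethyl)amino has the same heavy-atom count as diethylamino, the change gives an at least 170-fold higher number from compound 3 to compound 4 (2.23 log units; beyond the scatter), and the longer-chain groups give an at least 670-fold higher number from compound 2 to compound 4 (2.82 log units; beyond the scatter) and an at least 780-fold higher number from compound 1 to compound 4 (2.89 log units; beyond the scatter). At this position, then, heavy-atom count alone does not set the number, and this change costs far more than the earlier modest trims.

The change both adds a chain oxygen and leaves a hydrogen on the amino nitrogen, and these compounds cannot separate the two. A butylamino group, which keeps that hydrogen without the oxygen, or a bis(2-methoxyethyl)amino group, which keeps the oxygen without that hydrogen, would tell them apart.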